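Replacing dimethylamino with a larger aryl ether on compound 3

A few compounds are considered here, and "the series" means these few. Any claim that something is new, unique, unknown or untested is made for them only; others in the source may bear on it.

Three nitrofuran amides have been tested in an ADME assay on Vero cells (Chlorocebus sabaeus) for cytotoxicity, read by MTT assay, with a stated time of 48 h; on this read-out higher numbers stand for lower toxicity in this test and lower numbers for higher toxicity in this test. Compound 1 `O=C(NCCCc1ccccc1)c1ccc([N+](=O)[O-])o1` gives 11000 nM in this assay. Compound 2 `O=C(NC(c1ccccc1)C1CC1)c1ccc([N+](=O)[O-])o1` gives 22000 nM in this assay. Compound 3 `CN(C)c1ccc(C(C)(C)NC(=O)c2ccc([N+](=O)[O-])o2)cc1` gives 79000 nM in this assay, the highest of the three numbers, which marks it as the least toxic of the three measured compounds; its gap to compound 2 and its wider gap to compound 1 both lie beyond the usual scatter.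

Compound 4 `COc1ccc(OCc2ccc(C(C)(C)NC(=O)c3ccc([N+](=O)[O-])o3)cc2)cc1` has not yet been measured. It differs from compound 3 in one place: (4-methoxyphenoxy)methyl in place of dimethylamino on an aromatic carbon. The group that enters is considerably larger than the one that leaves and brings a second aromatic ring into the molecule.

No measured pair among these compounds shows what such a swap does in this assay, so the expectation rests only on the three values above. Because compound 3 sits at 79000 nM, the highest point seen here, a move in the direction of somewhat higher toxicity, of modest size and close to the edge of the scatter, seems the more likely outcome; the step from compound 3 to compound 4 is estimated as a 2.0-fold lower number from compound 3 to compound 4 (0.30 log units; within the scatter). Compound 4 is therefore expected to give about 40000 nM in this assay, within a range of 12000 nM to 120000 nM.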

Compound 4, half-maximal cytotoxic concentration: > 120000 nM
Compound 4 ended at the assay's limit; the forecaster's own chance of this, stated with the estimate: 10%; at least 3.0-fold (0.47 log units) between middle value and limit.
By their numbers in this assay, from the lowest: compounds 1 and 2 (each within the scatter of the next); then compound 3. At a limit, above all of these: compound 4.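

In this assay, putting (4-methoxyphenoxy)methyl in place of dimethylamino on this aromatic carbon, para to a large group, gives an at least 1.5-fold higher number from compound 3 to compound 4 (0.18 log units; that floor lies within the scatter). Among the compounds shown here, this is the first direct comparison at this position, and it shows that dimethylamino is not needed to keep toxicity low in this test: a considerably larger group with a second aromatic ring and no nitrogen brings no sign of higher toxicity. The true size of the step remains unknown because compound 4 reached a limit of the assay and has no exact number: the limit of > 120000 nM in this assay, at which 1 of the 4 values shown sits.

On these data alone, one swap cannot separate the contributions of the second aromatic ring, the ether oxygen and the terminal methoxy group, so the part of the new group that matters in this test remains open. It is also unclear whether a simple ethyl ether, a morpholine, a carboxylic acid or a longer carbon chain on the same aromatic carbon would keep toxicity this low, or whether one of them would bring the number down towards those of the other compounds.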